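The source may hold more compounds than are shown below. What is called first, only, known or untested is meant among the compounds shown, and "the series" means these compounds.

Of the compounds shown here, three have been measured in an assay on cell membranes for displacement of a labelled ligand from Neuronal acetylcholine receptor; alpha4/beta2 (Rattus norvegicus); on this read-out higher numbers stand for weaker inhibition and lower numbers for stronger inhibition. Compound 1 `COc1ccc(Nc2ccc(N3CC4CC(C3)N4)nn2)cc1` gives 578 nM in this assay, the highest of the three numbers. Compound 2 `c1ccc(Nc2ccc(N3CC4CC(C3)N4)cn2)cc1` gives 2.66 nM, and compound 3 `Oc1ccc(Nc2ccc(N3CC4CC(C3)N4)cn2)cc1` gives 7.1 nM; both share a core that differs from that of compound 1. For the measured compounds named here, the one single-point step known so far is a 2.7-fold higher number from compound 2 to compound 3 (0.43 log units; beyond the scatter), a change that touches a different part of the molecule than the one altered here.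

Compound 4 `Clc1ccc(Nc2ccc(N3CC4CC(C3)N4)nn2)cc1` is the unmeasured compound. It keeps the core of compound 1 and differs only in one group: chloro in place of methoxy on an aromatic carbon. Going by the values given here, no measured pair shows the swap of methoxy for chloro, so the expectation rests on the large gap between compound 1 and the other two, which comes with the core change rather than with any single substituent. A step no larger than the scatter is therefore expected, giving compound 4 an estimated 450 nM, with a likely range from 120 nM to 1700 nM, meaning an expected step of a 1.3-fold lower number from compound 1 to compound 4 (0.11 log units; within the scatter).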

Compound 4, inhibition constant: 90.4 nM
Estimate against measurement, compound 4: 5.0-fold (0.70 log units) above; measured number below the stated range.
By their numbers in this assay, from the lowest: compound 2; then compound 3; then compound 4; then compound 1.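

Swapping methoxy for chloro on the aromatic ring, para to a large group, gives a 6.4-fold lower number from compound 1 to compound 4 (0.81 log units; beyond the scatter) in this assay, so this position does affect the read-out on this core, and the lower number means stronger inhibition. For the compounds shown here, the only earlier step, a 2.7-fold higher number from compound 2 to compound 3 (0.43 log units; beyond the scatter), comes from a different core and could not show this. The two groups differ in heavy atoms and in hydrogen-bond acceptors, but a single pair cannot separate these differences, and no measurement here accounts for the step.

As far as these compounds go, it remains open whether a fluoro, a methyl or an amine at this position would give a number closer to that of chloro or of methoxy. From the compounds shown here alone, the same swap on the core of compound 2 is also open, so the size of this step may hold only for the core of compound 1.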